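The source may report more compounds than this note shows. Statements on the series, on what has been measured and on what is new or still open speak of the compounds shown alone.

Three compounds have a measured outcome in a functional assay on HepG2 cells (Homo sapiens) for antiproliferative activity, read by MTT assay, with a stated time of 48 h (a higher number here means a weaker inhibitor, a lower number a stronger inhibitor), and a fourth awaits its own. Compound 1 `COc1ccc(-c2c(Nc3ccc(F)cc3)c3ccc(OC)cc3oc2=O)cc1` carries a (4-fluorophenyl)amino group on its core. In this assay compound 1 reaches only a limit of the assay, > 100000 nM, which is a boundary rather than a number. Compound 2 `COc1ccc(-c2c(Nc3ccc(C)c(O)c3)c3ccc(OC)cc3oc2=O)cc1` differs from compound 1 in one place: 3-hydroxy-4-methylphenyl in place of 4-fluorophenyl on a nitrogen on an aromatic ring. In this assay compound 2 gives 22500 nM, and the step is an at least 4.4-fold lower number from compound 1 to compound 2 (0.64 log units; beyond the scatter).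

Compound 3 `COc1ccc2oc(=O)c(C(=O)C(F)(F)F)c(Nc3ccc(F)cc3)c2c1` rests on a different core, and the difference between the two cores is not broken down here. In this assay compound 3 also reports only a limit, > 100000 nM. Two of the three measured values therefore sit at the same boundary (the limit of > 100000 nM in this assay, at which 2 of the 3 values shown sit).

Compound 4 `COc1ccc2oc(=O)c(C(=O)C(F)(F)F)c(Nc3ccc(C)c(O)c3)c2c1` stands to compound 3 as compound 2 stands to compound 1, the same change at the same place: 3-hydroxy-4-methylphenyl in place of 4-fluorophenyl on a nitrogen on an aromatic ring. The expected step is an at least 2.5-fold lower number from compound 3 to compound 4 (0.39 log units; beyond the scatter), which rests on the earlier step of an at least 4.4-fold lower number from compound 1 to compound 2 (0.64 log units; beyond the scatter) and on the limit reported for compound 3, > 100000 nM. Since compound 3 is only bounded, the starting point is itself uncertain, and the change may well leave compound 4 at the boundary again. Compound 4 is estimated in this assay at 40000 nM, with a likely range from 15000 nM to 150000 nM, and with a real chance that the assay reports only a limit.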

Compound 4, half-maximal inhibitory concentration: 6710 nM
For compound 4 the middle estimate is 6.0-fold (0.78 log units) above the measured one; measured number below the stated range.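

In this assay the change from the (4-fluorophenyl)amino group to the (3-hydroxy-4-methylphenyl)amino group lowers the number on the second core as it does on the first, with an at least 14-fold lower number from compound 3 to compound 4 (1.17 log units; beyond the scatter), and the two steps compare as follows: the same change on two cores in this assay, an at least 4.4-fold lower number (0.64 log units; beyond the scatter) from compound 1 to compound 2 and an at least 14-fold lower number (1.17 log units; beyond the scatter) from compound 3 to compound 4; the limit leaves it open whether they differ. Compound 3 gives only > 100000 nM, which is a limit of the assay and not a number. The two pairs therefore show that the direction of the change carries over from one core to the other, but they do not show that its size is the same on both cores or that one core responds more strongly, and two pairs set no rule for any further core.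

The hydroxy and methyl groups enter together in both pairs, so the compounds shown leave open which of the two goes with the lower number, and a phenyl ring bearing only one of them would separate the two. Also open, as far as these compounds go, is how the series would respond to a methoxy group in place of the hydroxy group, or to an amine or a carboxylic acid on the same ring.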